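A few compounds are considered here, and "the series" means these few. Any claim that something is new, unique, unknown or untested is made for them only; others in the source may bear on it.

Three compounds built on the same core, a saturated ring that carries a basic nitrogen and a ketone, have each been tested in an assay on isolated protein for inhibition of sodium-dependent dopamine transporter (Homo sapiens); a lower number here means a stronger inhibitor, a higher number a weaker inhibitor. Compound 1 `CC(C)(C)CCC1(C(=O)c2cc(F)c(Cl)c(Cl)c2)CCNC1` gives 10 nM in this assay. Compound 2 `O=C(c1ccc2[nH]ccc2c1)C1(Cc2ccccc2)CCCNC1` gives 63.1 nM in this assay. Compound 3 `CC(C)(C)CCC1(C(=O)c2ccc3ccccc3n2)CCNC1` gives 3.98 nM in this assay, the lowest of the three numbers, with a gap to compound 1 and a wider gap to compound 2 that both lie beyond the scatter of repeated measurements.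

Compound 4 `Cc1cccc2nc(C(=O)C3(CCC(C)(C)C)CCNC3)ccc12` has not yet been measured. It differs from compound 3 in a single place: methyl in place of hydrogen on an aromatic carbon.

Among the compounds with values here, no measured pair in this set differs by such a methyl alone, so there is no earlier step to lean on. The change is the addition of one methyl group and nothing more, and the expectation for compound 4 in this assay is a step, a 1.0-fold higher number from compound 3 to compound 4 (0.00 log units; within the scatter), that stays within the scatter in either direction. Compound 4 is therefore estimated at 4 nM in this assay, within a range from 1.5 nM to 12 nM.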

Compound 4, inhibition constant: 1 nM
Beside the measured number, compound 4's estimate is 4.0-fold (0.60 log units) above it; the measured number lies below the stated range.
By their numbers in this assay, from the lowest: compound 4; then compound 3; then compound 1; then compound 2.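

In this assay the swap of hydrogen for methyl on an aromatic carbon gives a 4.0-fold lower number from compound 3 to compound 4 (0.60 log units; beyond the scatter) and so shows that this single added carbon is enough to move the number, here toward a stronger inhibitor. Within the data shown here, the position, on the six-membered aromatic ring of carbon only within the fused system of two rings, therefore accepts a methyl and responds to it, which no earlier compound could show. Nothing available explains why the number falls.

Going by these compounds, whether an ethyl, a methoxy or a chlorine on this same carbon would push the number further down remains open, as does whether a methyl on the other carbons of that ring would have the same effect. This one pair also cannot say whether the methyl would act alike with a different chain on the shared core.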